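From methoxy to fluoro on the aromatic ring

The compounds below may be only part of what the source reports. "The series", "measured", "known", "first", "only" and "open" are said of these compounds alone.

In a functional assay on A549 cells (Homo sapiens) for antiproliferative activity, read by CCK-8 assay, with a stated time of 72 h (a lower number here means a stronger inhibitor, a higher number a weaker inhibitor), compound 1 (`Nc1ccccc1NC(=O)c1ccc(COc2ccc(Cl)cc2)cc1`) reads > 32000 nM which is a limit of the assay and not a number. Among the measured compounds shown here, compound 2 (`COc1ccc(OCc2ccc(C(=O)Nc3ccccc3N)cc2)cc1`) gives 5530 nM and this is the only true number so far.

The next change leads to compound 3 (`Nc1ccccc1NC(=O)c1ccc(COc2ccc(F)cc2)cc1`), with fluoro in place of methoxy on an aromatic carbon, para to a large group (fluoro in place of methoxy on an aromatic carbon). For the measured compounds named here, one measured step bears on this place: an at least 5.7-fold lower number from compound 1 to compound 2 (0.76 log units; beyond the scatter) with methoxy in place of chloro. That step starts from a limit. Going by the values given here, it is the only guide available, and it favours methoxy over chloro at this carbon. Compound 3 gives up that methoxy, so part of the step is expected to be lost, though one step is thin support for any firm size. The expected move is a 2.2-fold higher number from compound 2 to compound 3 (0.34 log units; beyond the scatter) toward a higher number and thus a weaker inhibitor. Compound 3 is estimated at 12000 nM (expected range 4000 nM to 32000 nM).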

Compound 3, half-maximal inhibitory concentration: 5370 nM
The estimate for compound 3 lay 2.2-fold (0.35 log units) above the measured number, within the range that was stated.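

Within this assay, methoxy and fluoro on this aromatic carbon cannot be told apart: a 1.0-fold lower number from compound 2 to compound 3 (0.01 log units; within the scatter), so the gain seen on leaving chloro is not tied to the methoxy group, and its oxygen is not required to reach this level of activity. Chloro now stands apart from both other groups at this place, with an at least 5.9-fold lower number from compound 1 to compound 3 (0.77 log units; beyond the scatter) matching the earlier at least 5.7-fold lower number from compound 1 to compound 2 (0.76 log units; beyond the scatter), a pattern that rests on these three compounds alone and that none of them goes against. Compound 1 carries a limit and not a number, so both steps give only a minimum size: the limit of > 32000 nM in this assay, at which 1 of the 3 values shown sits.

On these data alone, how a plain hydrogen, a methyl, a bromo or a trifluoromethyl group on this carbon would read in this assay stays open, and with it whether chloro is a lone exception or one end of a wider trend. Also open, as far as these compounds go, is whether the match between compound 2 and compound 3 would extend to an amine or a carboxylic acid at this place, or would survive a longer chain in place of the link to this ring.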